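The source may report more compounds than this note shows. Statements on the series, on what has been measured and on what is new or still open speak of the compounds shown alone.

In a functional assay with Oryctolagus cuniculus as the target (a higher number here means a weaker inhibitor, a lower number a stronger inhibitor), three compounds sharing one core have been tested. Compound 1 `CC/N=C(/N)Nc1nc(-c2ccc(OC)cc2)c(-c2ccc(OC)cc2)s1` gives > 100 nM, which is a limit and not a number. Compound 2 `COc1ccc(-c2nc(C(=O)N(C)C)sc2-c2ccc(OC)cc2)cc1` gives < 100 nM, also a limit. From the compounds shown here alone, compound 3 `CCOC(=O)/C(C#N)=C/c1nc(-c2ccc(OC)cc2)c(-c2ccc(OC)cc2)s1` gives < 10 nM, again a limit, so its exact standing is unknown.

Compound 4 `CCOC(=O)/C=C/c1nc(-c2ccc(OC)cc2)c(-c2ccc(OC)cc2)s1` carries 2-(ethoxycarbonyl)ethenyl in place of 2-cyano-2-(ethoxycarbonyl)ethenyl on an aromatic carbon. Within the data shown here, no measured step makes this exact change. The nearest guide is an at least 10-fold lower number from compound 1 to compound 3 (1.00 log units; beyond the scatter), a different swap on that aromatic carbon, while a number no higher from compound 1 to compound 2 (the limit leaves the size open) and a step that the two limits leave unreadable from compound 2 to compound 3 leave their sizes open. Given an at least 10-fold lower number from compound 1 to compound 3 (1.00 log units; beyond the scatter), a modest move towards a higher number is expected in this assay. The expected change is an at least 1.5-fold higher number from compound 3 to compound 4 (0.17 log units; that floor lies within the scatter). For compound 4 the estimated value is 15 nM, with an expected range of 2 nM to 100 nM.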

Compound 4, half-maximal inhibitory concentration: 20 nM
Compound 4: middle estimate off by 1.3-fold (0.12 log units), on the low side; the range from low to high includes it.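

In this assay, taking the nitrile off the 2-cyano-2-(ethoxycarbonyl)ethenyl group gives an at least 2.0-fold higher number from compound 3 to compound 4 (0.30 log units; that floor lies within the scatter). That step is only a floor, since compound 3 has a limit and not a number: the limit of < 10 nM in this assay, at which 1 of the 4 values shown sits. The nitrile is also not needed for compound 4 to stand clear of compound 1, with an at least 5.0-fold lower number from compound 1 to compound 4 (0.69 log units; beyond the scatter).

The step from compound 2 to compound 4 cannot be read. From the compounds shown here alone, the true size of the nitrile step stays open, as does the effect of a carboxylic acid in place of the ethoxycarbonyl group.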